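Iodo in place of methyl on the sulfonamide aryl ring

The source may hold more compounds than are shown below. What is called first, only, known or untested is meant among the compounds shown, and "the series" means these compounds.

In an assay on CHO cells for binding affinity to integrin alpha-1 (Homo sapiens), read by WST assay, with a stated time of 2 h (on this read-out higher numbers stand for an effect only at larger amounts of compound and lower numbers for an effect already at smaller amounts), compound 1 `O=C(c1ccccc1)c1cccc(NS(=O)(=O)c2ccc(Cl)cc2Cl)c1` gives 17000 nM. Compound 2 `Cc1ccc(S(=O)(=O)Nc2ccc(C(=O)c3ccccc3)cc2)cc1` is reported in this assay as "not active" (no number reported), and compound 3 `Cc1ccc(S(=O)(=O)Nc2cccc(C(=O)c3ccccc3)c2)cc1` is reported in this assay as "not active" (no number reported), so no single number stands for compound 3; it is one of two entries without a number, and only compound 1 carries one. Compound 4 `O=C(c1ccccc1)c1cccc(NS(=O)(=O)c2ccc(I)cc2)c1` differs from compound 3 by iodo in place of methyl on an aromatic carbon. Going by the values given here, no step between measured compounds is available, so the size and direction of this change in this assay cannot be read from the data; an effect only at large amounts of compound is expected. Compound 4 is estimated at 30000 nM, with a range from 8000 nM to 120000 nM, and a report without a number is also considered likely.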

Compound 4, half-maximal effective concentration: 40000 nM
Beside the measured number, compound 4's estimate is 1.3-fold (0.12 log units) below it; the range from low to high includes it.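

Iodo in place of methyl turns a "not active" entry into a number: compound 4 has a value in this assay, while compound 3 has none, so the step between them cannot be read. The 4-iodophenyl group also falls short of the 2,4-dichlorophenyl group, with a 2.4-fold higher number from compound 1 to compound 4 (0.37 log units; beyond the scatter). Nothing available explains either result.

Going by these compounds, it remains open whether bromo or an amine in place of the iodo would also give a number in this assay. Also open, on these data alone, is whether iodo would give a number on the core of compound 2.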